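Swapping the Aryl Group: From Compound 3 to Compound 4

A few compounds are considered here, and "the series" means these few. Any claim that something is new, unique, unknown or untested is made for them only; others in the source may bear on it.

Compound 1 `Fc1ccc(-c2cc3c(cn2)ncn3-c2ccc(OC(F)F)cc2)c(Cl)c1`: 90 nM
Compound 2 `Cc1cc(Cl)ccc1-c1cc2c(cn1)ncn2-c1ccc(OC(F)F)cc1`: 28 nM
Compound 3 `Cc1cc(F)c(F)cc1-c1cc2c(cn1)ncn2-c1ccc(OC(F)F)cc1`: 220 nM

The three measured compounds share one core and differ only in the aryl group on an aromatic carbon. In a functional assay on HL-60 cells (Homo sapiens) for activation, read by flow cytometry, with a stated time of 4 days (on this read-out higher numbers stand for an effect only at larger amounts of compound and lower numbers for an effect already at smaller amounts), compound 3 gives the highest number of the three, with 220 nM. The steps leading to it are a 2.4-fold higher number from compound 1 to compound 3 (0.39 log units; beyond the scatter) and a 7.9-fold higher number from compound 2 to compound 3 (0.90 log units; beyond the scatter).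

Compound 4 `Cc1nc(F)ccc1-c1cc2c(cn1)ncn2-c1ccc(OC(F)F)cc1` carries a new aryl group at the same position: 6-fluoro-2-methylpyridin-3-yl in place of 4,5-difluoro-2-methylphenyl on an aromatic carbon. Both earlier steps changed the same aryl group and were modest in size, and none of them put a ring nitrogen into that group, so the measured data give no direct guide for that part of the change. A modest step is therefore expected in this assay, most likely toward a lower number, since compound 3 already stands at the top of the range. The estimated step is a 1.5-fold lower number from compound 3 to compound 4 (0.17 log units; within the scatter), and for compound 4 the expected value is 150 nM, within 50 nM to 450 nM.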

Compound 4, half-maximal effective concentration: 2000 nM
For compound 4 the middle estimate is 13-fold (1.12 log units) below the measured one; the measured number lies above the stated range.
By their numbers in this assay, from the lowest: compound 2; then compound 1; then compound 3; then compound 4.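

In this assay the swap to 6-fluoro-2-methylpyridin-3-yl brings a 9.1-fold higher number from compound 3 to compound 4 (0.96 log units; beyond the scatter) and puts compound 4 at the top of the series, with still wider gaps in a 22-fold higher number from compound 1 to compound 4 (1.35 log units; beyond the scatter) and in a 71-fold higher number from compound 2 to compound 4 (1.85 log units; beyond the scatter) as well. Among the steps shown, only those into compound 4 place a ring nitrogen and a hydrogen-bond acceptor in this aryl group, and they show that the read-out at this place can shift much further than the carbon-only aryl groups had indicated. Nothing in the data shown accounts for the rise.

The compounds shown leave open whether the ring nitrogen or the altered fluorine substitution carries this step. Also open, going by these compounds, is how this assay would respond to a methoxy group or a nitrile in place of the fluorine on that ring.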